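Moving the trifluoromethyl around the pyrimidine ring

The source may hold more compounds than are shown below. What is called first, only, known or untested is meant among the compounds shown, and "the series" means these compounds.

Measured compounds:
Compound 1 `CCOC(=O)c1c(C)noc1OCC(=O)[C@H](CC(=O)O)NC(=O)[C@@H](NC(=O)COc1cccc2ccccc12)C(C)C` — in a functional assay on Jurkat cells (Homo sapiens) for inhibition (on this read-out lower numbers stand for stronger inhibition and higher numbers for weaker inhibition), compound 1 gives > 200000 nM, which is a limit of the assay and not a number.
Compound 2 `Cc1cc(OCC(=O)[C@H](CC(=O)O)NC(=O)[C@@H](NC(=O)COc2cccc3ccccc23)C(C)C)nc(C)n1` — in this assay compound 2 gives > 200000 nM, again a limit of the assay.
Compound 3 `CC(C)[C@H](NC(=O)COc1cccc2ccccc12)C(=O)N[C@@H](CC(=O)O)C(=O)COc1ccnc(C(F)(F)F)n1` — in this assay compound 3 gives 37000 nM.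

Compound 3 is the only one of the three with a measured number; the other two sit at a limit (the limit of > 200000 nM in this assay, at which 2 of the 3 values shown sit). The step of an at least 5.4-fold lower number from compound 1 to compound 3 (0.73 log units; beyond the scatter) and the step of an at least 5.4-fold lower number from compound 2 to compound 3 (0.73 log units; beyond the scatter) both show that the heteroaryl group on this oxygen matters, while the step that the two limits leave unreadable from compound 1 to compound 2 cannot be read.

Compound 4 `CC(C)[C@H](NC(=O)COc1cccc2ccccc12)C(=O)N[C@@H](CC(=O)O)C(=O)COc1nccc(C(F)(F)F)n1` keeps every atom of compound 3 and differs only in 4-(trifluoromethyl)pyrimidin-2-yl in place of 2-(trifluoromethyl)pyrimidin-4-yl on an oxygen on a saturated carbon. Among the measured compounds shown here, no measured pair shows what such a swap within the same ring does; the two steps that bear on it show only that exchanging one heteroaryl for another can move the number in this assay by more than the scatter. The expected step of a 1.2-fold higher number from compound 3 to compound 4 (0.09 log units; within the scatter) is therefore small, but with a wide margin either way. Compound 4 is estimated at 45000 nM in this assay, within 10000 nM to 200000 nM.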

Compound 4, half-maximal inhibitory concentration: > 200000 nM
Compound 4: only a limit was reported; the forecaster's own chance of this, stated with the estimate: 25%; middle value at least 4.4-fold (0.64 log units) away from the limit.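

Among the compounds shown here, compound 4 shows what the earlier compounds could not: the arrangement of a single heteroaryl group can matter in this assay, seen in the step of an at least 5.4-fold higher number from compound 3 to compound 4 (0.73 log units; beyond the scatter). Earlier steps exchanged one substituted ring for another, whereas here the group that leaves and the group that enters have the same atoms and the same counts, so the presence of a trifluoromethyl-bearing pyrimidine on this oxygen does not by itself give a measurable number. The steps from compound 1 and compound 2 to compound 4 cannot be read, and compound 3 remains the only compound with a number, the others sharing one limit: the limit of > 200000 nM in this assay, at which 3 of the 4 values shown sit.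

Because compound 4 sits at a limit, the compounds shown leave open how large the step from compound 3 really is, and whether it comes from the new place of the trifluoromethyl, the new link of the ring to the oxygen, or both: the limit of > 200000 nM in this assay, at which 3 of the 4 values shown sit. They also leave open whether a nitrile or a methyl in place of the trifluoromethyl on the 2-substituted pyrimidin-4-yl ring would give a lower number than compound 3.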